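The source may hold more compounds than are shown below. What is called first, only, known or untested is meant among the compounds shown, and "the series" means these compounds.

In a functional assay on HeLa cells (Homo sapiens) for cytotoxicity, read by WST assay, with a stated time of 48 h (a lower number here means a stronger inhibitor, a higher number a weaker inhibitor), compound 3 `COc1cc(C(c2ccc(O)c(OC)c2)[C@@H](C)[C@H](C)CO)ccc1O` reads > 100000 nM, which is a limit of the assay and not a number. Its two relatives give numbers: compound 1 `COC[C@H](C(C)C)C(c1ccc(O)c(OC)c1)c1ccc(O)c(OC)c1` reads 76000 nM and compound 2 `COc1cc(C(c2ccc(O)c(OC)c2)[C@H](C)C(C)C)ccc1O` reads 16000 nM.

Compound 4 `COc1cc(C(c2ccc(O)c(OC)c2)[C@H](C)[C@@H](C)CO)ccc1O` is the counterpart of compound 3: the two compounds have the same atoms and bonds and differ only in configuration as drawn: 2 of 2 stereo elements differ (all stereocentres are inverted: mirror images); a stereocentre at a saturated chain carbon is drawn R in compound 3 and S in compound 4; a stereocentre at a saturated chain carbon is drawn S in compound 3 and R in compound 4. No measured pair in this series isolates a change of configuration, so no step shown sizes this one directly. The nearest guides are changes to the chain itself. The step of a 4.8-fold lower number from compound 1 to compound 2 (0.68 log units; beyond the scatter) and the step of an at least 6.2-fold higher number from compound 2 to compound 3 (0.79 log units; beyond the scatter) both lie beyond the scatter, though they are modest or only bounded. The step of an at least 1.3-fold higher number from compound 1 to compound 3 (0.11 log units; that floor lies within the scatter) has a floor within the scatter. Even these changes of atoms stay moderate, whereas compound 4 keeps every atom and bond of compound 3, so a large shift is not expected.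

The expectation starts from compound 3, whose limit of > 100000 nM leaves its true position unknown. From the compounds shown here alone, no step beyond the scatter is expected in this assay, and the direction stays open, with the estimate being an at least 1.1-fold lower number from compound 3 to compound 4 (0.04 log units; that floor lies within the scatter). A reading at the same limit would be no surprise. For compound 4 the estimated value is 90000 nM, with an expected range from 35000 nM to 200000 nM.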

Compound 4, half-maximal inhibitory concentration: > 100000 nM
Compound 4: no number, only a limit (the forecaster's own chance of this, stated with the estimate: 50%); middle value at least 1.1-fold (0.04 log units) from the limit.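

In this assay compound 4 gives > 100000 nM, which is a limit of the assay and not a number. Hydroxy in place of hydrogen on a saturated chain carbon, four bonds along the chain from two aromatic carbons, gives an at least 6.2-fold higher number from compound 2 to compound 4 (0.79 log units; beyond the scatter), so the loss seen with compound 3 now also appears with the opposite configuration as drawn. The remaining comparison, an at least 1.3-fold higher number from compound 1 to compound 4 (0.11 log units; that floor lies within the scatter), has its floor within the scatter, and the step between the two mirror images cannot be read: the limit of > 100000 nM in this assay, at which 2 of the 4 values shown sit.

Whether configuration at these two stereocentres changes the read-out at all stays open, since the pair gives no number on either side: the fact that compounds 3 and 4 differ only in the configuration as drawn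

Also open, from the compounds shown here alone, is whether an amine or a carboxylic acid in place of the hydroxy on this chain, or a longer chain carrying the hydroxy, would stay at the limit in this assay or return a number.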